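Swapping Bromo for Nitro: Expected Cytotoxicity of Compound 4

The source may hold more compounds than are shown below. What is called first, only, known or untested is meant among the compounds shown, and "the series" means these compounds.

Measured compounds:
Compound 1, `O=C(N/N=C/c1ccccc1)c1cnccn1`, gives 75%.
Compound 2, `O=C(N/N=C/c1cccc(Br)c1)c1cnccn1`, gives 100%.
Compound 3, `CCOc1ccc(/C=N/NC(=O)c2cnccn2)cc1`, gives 98%.

All three were tested in an ADME assay on J774 cells (Mus musculus) for cytotoxicity, read by MTT assay, with a stated time of 48 h, tested at 100 ug/mL; a lower number here means a stronger effect, a higher number a weaker effect of the compound at the concentration tested. On these numbers compound 2 and compound 3 cannot be told apart, while compound 1 sits clearly lower, that is, compound 1 shows the stronger effect of the three. Two measured steps lead away from compound 1: bromo in place of hydrogen on an aromatic carbon gives a number 25 percentage points higher from compound 1 to compound 2 (beyond the scatter), and ethoxy in place of hydrogen on an aromatic carbon gives a number 23 percentage points higher from compound 1 to compound 3 (beyond the scatter). Both added groups raised the number to the same extent.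

Compound 4, `O=C(N/N=C/c1cccc([N+](=O)[O-])c1)c1cnccn1`, differs from compound 2 as follows: nitro in place of bromo on an aromatic carbon. Among the measured compounds shown here, no measured step exchanges one group for another at that carbon, so the only guide is that two different groups there gave numbers within the scatter of each other. The step of a number 5 percentage points lower from compound 2 to compound 4 (within the scatter) is therefore expected to stay within the scatter. For compound 4 the estimate in this assay is 95%, with a range from 78% to 100%.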

Compound 4, a percentage reported as activity, at one concentration (the size of the read-out at that concentration, not a potency): 85%
The estimate for compound 4 lay 10 percentage points above the measured number, and the stated range covers the measured number.
By their numbers in this assay, from the lowest: compounds 1 and 4 (each within the scatter of the next); then compounds 3 and 2 (each within the scatter of the next).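

In this assay, the identity of the group at this aromatic carbon matters, not only whether a group is there: nitro in place of bromo gives a number 15 percentage points lower from compound 2 to compound 4 (beyond the scatter) and so separates two groups at the same carbon. Set against hydrogen at that carbon, nitro gives a number 10 percentage points higher from compound 1 to compound 4 (within the scatter) and compound 4 therefore cannot be told apart from compound 1, whereas bromo gave a number 25 percentage points higher from compound 1 to compound 2 (beyond the scatter) in the same comparison. Placing a group on this ring thus does not always go with a clear step away from compound 1, and compound 4 is the one that goes against that earlier impression.

On these data alone, whether an amine or a carboxylic acid at this carbon would track with bromo or with nitro remains open. No measurement shown here explains why nitro and bromo differ in this assay.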